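The source may hold more compounds than are shown below. What is called first, only, known or untested is meant among the compounds shown, and "the series" means these compounds.

Working notes on the series, read in an ADME assay on MT4 cells (Homo sapiens) for cytotoxicity, read by MTT assay, with a stated time of 4 days; on this read-out lower numbers stand for higher toxicity in this test and higher numbers for lower toxicity in this test. Among the measured compounds shown here, compound 1 `CCCNc1nc(C(C)c2c(F)cccc2F)c(C)c(=O)[nH]1` gives 35000 nM, the only true number so far. Compound 2 `CCC(c1nc(N(C)C)[nH]c(=O)c1C)c1c(F)cccc1F` is reported only as a limit, > 81000 nM. For the measured compounds named here, compound 1 therefore cannot yet be ranked firmly, and no step between two measured compounds is available to calibrate the next change. The next compound is compound 3 `CCN(C)c1nc(C(C)c2c(F)cccc2F)c(C)c(=O)[nH]1`, which has the same atoms as compound 1, joined differently: ethyl(methyl)amino in place of propylamino on an aromatic carbon. The exchange sits on an aromatic carbon between two ring nitrogen atoms. With compound 1 at 35000 nM as the only anchor, a small move towards lower toxicity in this test is expected, barely beyond the usual scatter. The expected step is a 1.4-fold higher number from compound 1 to compound 3 (0.15 log units; within the scatter). For compound 3 the estimated value is 50000 nM, with an expected range of 22000 nM to 110000 nM.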

Compound 3, half-maximal cytotoxic concentration: 81000 nM
Compound 3: middle estimate off by 1.6-fold (0.21 log units), on the low side; the measured number falls inside the stated range.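

At this position, on an aromatic carbon between two ring nitrogen atoms, the series now has its first readable step: in this assay, ethyl(methyl)amino in place of propylamino gives a 2.3-fold higher number from compound 1 to compound 3 (0.36 log units; beyond the scatter). The exchange keeps the 4 heavy atoms and changes the hydrogen-bond donor count of the group from 1 to 0, so rearranging the same atoms at this carbon is enough to move the read-out beyond the usual scatter. Compound 2 remains a limit rather than a number and gives no step of its own: the limit of > 81000 nM in this assay, at which 1 of the 3 values shown sits.

A single pair cannot separate the lost donor from the changed shape of the chain. As far as these compounds go, how a cyclic amine such as pyrrolidine, or a longer chain such as butylamino, would read at this carbon stays open.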